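Swapping Naphthalenyl for Thiophenyl on a Shared Core

The compounds below may be only part of what the source reports. "The series", "measured", "known", "first", "only" and "open" are said of these compounds alone.

Three measured compounds share one core and differ only in the group on a carbonyl carbon. Compound 1 `O=C(NC(=S)N1CCc2c(OCCCCCOc3ccc(Cl)cc3)cccc21)Oc1ccccc1` carries a phenoxy group there. In an ADME assay on Huh-7 cells (Homo sapiens) for cytotoxicity (on this read-out lower numbers stand for higher toxicity in this test and higher numbers for lower toxicity in this test), compound 1 gives > 50000 nM, which is a limit of the assay rather than a number. Compound 2 `CCCC(=O)NC(=S)N1CCc2c(OCCCCCOc3ccc(Cl)cc3)cccc21` carries propyl instead. In this assay compound 2 gives > 50000 nM, again a limit. Compound 3 `O=C(NC(=S)N1CCc2c(OCCCCCOc3ccc(Cl)cc3)cccc21)c1ccc2ccccc2c1` carries naphthalen-2-yl. In this assay compound 3 gives > 50000 nM, also a limit. Because all three values sit at the limit of > 50000 nM in this assay, at which 3 of the 3 values shown sit, the steps a step that the two limits leave unreadable from compound 1 to compound 2, a step that the two limits leave unreadable from compound 1 to compound 3 and a step that the two limits leave unreadable from compound 2 to compound 3 cannot be read as sizes. Compound 3 thus stands where every measured compound stands, at the same limit.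

Compound 4 `O=C(NC(=S)N1CCc2c(OCCCCCOc3ccc(Cl)cc3)cccc21)c1cccs1` differs from compound 3 by thiophen-2-yl in place of naphthalen-2-yl on a carbonyl carbon. Within the data shown here, no measured step gives a readable size for a change of this kind, so for compound 4 no step beyond the scatter is expected. The expected step for compound 4 is a step that the limit leaves unreadable from compound 3 to compound 4. Compound 4 is therefore estimated at 80000 nM, with a range from 30000 nM to 200000 nM, most likely reported again only as a limit.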

Compound 4, half-maximal cytotoxic concentration: 10700 nM
For compound 4 the middle estimate is 7.5-fold (0.87 log units) above the measured one; measured number outside the range, below it.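

In this assay the change to thiophen-2-yl on a carbonyl carbon brings an at least 4.6-fold lower number from compound 3 to compound 4 (0.66 log units; beyond the scatter) and an at least 4.6-fold lower number from compound 2 to compound 4 (0.66 log units; beyond the scatter) and also an at least 4.6-fold lower number from compound 1 to compound 4 (0.66 log units; beyond the scatter) as the size of the change. The group at this position can therefore shift the read-out toward higher toxicity in this test, which the phenoxy, propyl and naphthalen-2-yl compounds could not show on their own. As far as these compounds go, the full size of each step stays unknown because only compound 4 has an exact number: the limit of > 50000 nM in this assay, at which 3 of the 4 values shown sit.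

A furan-2-yl or a plain phenyl group on the same carbonyl carbon could show whether other single aromatic rings also give a readable number. From the compounds shown here alone, with compound 4 alone, it remains open whether the lower number goes with the sulfur atom or with the five-membered aromatic ring.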